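The source may report more compounds than this note shows. Statements on the series, on what has been measured and on what is new or still open speak of the compounds shown alone.

Measured so far:
compound 1, `COC(=O)c1ccc(NCc2cncn2Cc2cccc(C)c2)cc1-c1ccccc1` — > 10000 nM
compound 2, `COC(=O)c1ccc(NCc2cncn2Cc2ccc(F)cc2)cc1-c1ccccc1` — "not determined" (no result reported)

The study looked at two compounds on a shared core in a toxicity assay on NIH3T3 cells (Mus musculus) for cytotoxicity, read by resazurin assay; on this read-out higher numbers stand for an effect only at larger amounts of compound and lower numbers for an effect already at smaller amounts. For compound 1 the result in this assay is a limit of the assay, > 10000 nM, not a number. For compound 2 the assay gives no result, "not determined" (no result reported), so compound 2 stands nowhere on the numbers shown; the only value alongside it is the limit of > 10000 nM in this assay, at which 1 of the 2 values shown sits.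

Compound 3, `COC(=O)c1ccc(NCc2cncn2Cc2cccc(C#N)c2)cc1-c1ccccc1`, is the next compound to be measured. It differs from compound 2 by 3-cyanophenyl in place of 4-fluorophenyl on a saturated chain carbon bound to an aromatic nitrogen.

Going by the values given here, no measured step on this core is known, so the size of the change expected in this assay can only be guessed: none beyond the scatter is the plain expectation, with the single known value being a limit. Compound 3 is therefore expected to give about 15000 nM in this assay, somewhere between 5000 nM and 50000 nM.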

Compound 3, half-maximal effective concentration: > 10000 nM
Compound 3: a limit, no number; the forecaster's own chance of this, stated with the estimate: 70%; the middle value lies beyond the limit too.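

Going by these compounds alone, compound 1 and compound 3 each give a limit of the assay rather than a number, so no step between them can be read in this assay. The compounds shown leave open whether any change on the shared core shifts this read-out at all.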